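This account rests on a few compounds, and the source may have more. Where it says the series, first, only, none or still open, it means among the compounds named here.

Compound 1, whose structure is `CCCCCn1c(N)nc2c(OC)cccc21`, gives 3740 nM in an assay on HEK293 cells for agonist activity at Toll-like receptor 8 (Homo sapiens), read by reporter gene assay; a lower number here means that less compound is needed, a higher number that more compound is needed for the effect. Compound 2, with the structure `CCCCCn1c(N)nc2c(F)cccc21`, is reported in this assay only as "not active" (no number reported): no single number stands for it, so its place among the values shown cannot be set more closely than that it gave no measurable effect where compound 1 did. For the measured compounds named here, the pair shows only that the methoxy compound has a number and the fluoro compound does not.

Compound 3, with the structure `CCCCCn1c(N)nc2c(Cl)cccc21`, carries the change (chloro in place of fluoro on an aromatic carbon). No measured step exists for this change, and no step of any kind is shown between the compounds given. Given that compound 2 produced no number in this assay, the expectation for compound 3 is weak activity at best, with a real chance that again no number is obtained. The estimated value for compound 3 in this assay is 12000 nM, with a range from 2500 nM to 60000 nM.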

Compound 3, half-maximal effective concentration: "not active" (no number reported)
Compound 3 has no reported number here; the estimate stays without a comparison.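

For the compounds shown here, compound 2 and compound 3 are both reported only as "not active" in this assay, so no step from fluoro to chloro can be read from them. No evidence bearing on this result is available. The compounds shown leave open how compound 2 and compound 3 would rank against each other on a numerical scale.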